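Phenyl in place of pentyl: compound 4 awaits measurement

This account rests on a few compounds, and the source may have more. Where it says the series, first, only, none or still open, it means among the compounds named here.

In an ADME assay on L929 cells (Mus musculus, culture collection number NCTC 929) for cytotoxicity, read by MTT assay, with a stated time of 72 h (a lower number here means a stronger inhibitor, a higher number a weaker inhibitor), compound 2 `CCCCCCCNC(=O)c1c(O)cc(C)oc1=O` gives 187000 nM and compound 3 `CCCCCCNC(=O)c1c(O)cc(C)oc1=O` gives 196000 nM, two values within the scatter of each other. For compound 1 `Cc1cc(O)c(C(=O)Nc2ccccc2)c(=O)o1` the result is a limit of the assay, > 200000 nM. Compound 4 `Cc1cc(O)c(C(=O)NCc2ccccc2)c(=O)o1` has phenyl in place of pentyl on a saturated chain carbon bound to an amide-type nitrogen. Among the measured compounds shown here, two measured steps bear on this change. Hydrogen in place of methyl on the chain gave a 1.0-fold higher number from compound 2 to compound 3 (0.02 log units; within the scatter), and hexyl in place of phenyl on an amide-type nitrogen gave an at least 1.0-fold lower number from compound 1 to compound 3 (0.00 log units; that floor lies within the scatter). Neither shows a change beyond the scatter, so none is expected here, and the estimated step is a 1.0-fold lower number from compound 3 to compound 4 (0.01 log units; within the scatter). Compound 4 is expected at 190000 nM, within an estimated range of 100000 nM to 280000 nM.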

Compound 4, half-maximal inhibitory concentration: > 200000 nM
Compound 4: a limit, no number; the forecaster's own chance of this, stated with the estimate: 40%; middle value at least 1.0-fold (0.02 log units) from the limit.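

In this assay compound 4 gives > 200000 nM as a limit of the assay, not a number. At this place on a saturated chain carbon bound to an amide-type nitrogen, phenyl in place of pentyl gives an at least 1.0-fold higher number from compound 3 to compound 4 (0.00 log units; that floor lies within the scatter) and phenyl in place of hexyl gives an at least 1.0-fold higher number from compound 2 to compound 4 (0.02 log units; that floor lies within the scatter) so the aromatic ring brings no step beyond the scatter toward a lower number. The true size of neither step can be read, because compound 4 stands at a limit: the limit of > 200000 nM in this assay, at which 2 of the 4 values shown sit.

As far as these compounds go, whether an amine, a carboxylic acid or a longer chain at this place would give a clearly lower number stays open.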